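Removing a Methyl From a Weakly Active Fused Core

The source may report more compounds than this note shows. Statements on the series, on what has been measured and on what is new or still open speak of the compounds shown alone.

Measured compounds:
- compound 1, `CCCc1nc(C)c2cnnc(O)n12`: 56800 nM
- compound 2, `Cc1nc(C(C)C)n2c(O)nncc12`: > 48000 nM (a limit)
- compound 3, `Cc1nc(C)n2c(O)nncc12`: > 48000 nM (a limit)

Among the measured compounds shown here, in a functional assay for inhibition, with Homo sapiens as the target (on this read-out lower numbers stand for stronger inhibition and higher numbers for weaker inhibition), compound 1 gives 56800 nM, the only number among the three. Compound 2 sits at a limit of this assay rather than a number. Compound 3 likewise sits at a limit. Both limits are the limit of > 48000 nM in this assay, at which 2 of the 3 values shown sit. The step that the limit leaves unreadable from compound 1 to compound 2 therefore cannot be sized, nor can a step that the limit leaves unreadable from compound 1 to compound 3, and a step that the two limits leave unreadable from compound 2 to compound 3 is unreadable from both ends.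

Compound 4, `CCCc1ncc2cnnc(O)n12`, keeps the propyl group of compound 1 and differs by hydrogen in place of methyl on an aromatic carbon. For the measured compounds named here, none of the measured steps touches this position, and none is readable anyway, so the series gives no measured step that bears directly on this change. All that is known is that compound 1 is weak and its two relatives are no better than a limit. Compound 4 is therefore expected to stay in the same weak range, with a step of a 1.1-fold higher number from compound 1 to compound 4 (0.02 log units; within the scatter) expected to be no more than the scatter. The estimate for compound 4 in this assay is 60000 nM, with a range from 25000 nM to 150000 nM.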

Compound 4, half-maximal inhibitory concentration: > 48000 nM
Compound 4: only a limit was reported; the forecaster's own chance of this, stated with the estimate: 50%; the middle value is on the limit's open side.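

In this assay compound 4 gives > 48000 nM, which is a limit and not a number. Among the compounds shown here, no step from compound 1 to compound 4 can therefore be read, and the same holds for the other steps: the limit of > 48000 nM in this assay, at which 3 of the 4 values shown sit. From the compounds shown here alone, how far compound 2, compound 3 and compound 4 lie from compound 1 stays open.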